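Swapping the aryl group on the shared core of compound 3

The compounds below may be only part of what the source reports. "The series", "measured", "known", "first", "only" and "open" are said of these compounds alone.

Compound 3, `CC(C)c1ccc(-c2nc(SCc3cn(CC(=O)NC(=O)Nc4ccccn4)nn3)nc(Nc3cccc(C(F)(F)F)c3)c2C#N)cc1`, stands second highest of the three numbers gathered so far: in a functional assay on B16-F10 cells (Mus musculus) for inhibition, read by MTT assay, with a stated time of 72 h (a lower number here means a stronger inhibitor, a higher number a weaker inhibitor), compound 3 gives 1700 nM. Compound 2, `CC(C)c1ccc(-c2nc(SCc3cn(CC(=O)NC(=O)Nc4ccccn4)nn3)nc(Nc3cccc(Cl)c3)c2C#N)cc1`, gives 1130 nM, and compound 1, `CC(C)c1ccc(-c2nc(SCc3cn(CC(=O)NC(=O)Nc4ccccn4)nn3)nc(Nc3ccc(F)cc3)c2C#N)cc1`, gives 7250 nM. The steps of a 6.4-fold lower number from compound 1 to compound 2 (0.81 log units; beyond the scatter) and a 4.3-fold lower number from compound 1 to compound 3 (0.63 log units; beyond the scatter) were both modest and beyond the scatter, while a 1.5-fold higher number from compound 2 to compound 3 (0.18 log units; within the scatter) stayed within it. Compound 4, `COc1ccccc1Nc1nc(SCc2cn(CC(=O)NC(=O)Nc3ccccn3)nn2)nc(-c2ccc(C(C)C)cc2)c1C#N`, carries the change (2-methoxyphenyl in place of 3-(trifluoromethyl)phenyl on a nitrogen on an aromatic ring). Going by the values given here, no measured step puts a 2-methoxyphenyl on this nitrogen, so the closest guidance is that the 4-fluorophenyl of compound 1 gave the highest number and each of the two 3-substituted aryls moved away from it by a step beyond the scatter. A return toward the range of compound 1 is judged about as likely as no change beyond the scatter, so a small upward step is expected, a 1.5-fold higher number from compound 3 to compound 4 (0.18 log units; within the scatter). Compound 4 is therefore estimated at 2600 nM, expected between 900 nM and 7500 nM.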

Compound 4, half-maximal inhibitory concentration: 34600 nM
The estimate for compound 4 lay 13-fold (1.12 log units) below the measured number; measured number outside the range, above it.
By their numbers in this assay, from the lowest: compounds 2 and 3 (each within the scatter of the next); then compound 1; then compound 4.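

In this assay, going by these compounds alone, the 2-methoxyphenyl group shows that the aryl group on this nitrogen can cost far more than the earlier compounds suggested, with large steps both against 3-(trifluoromethyl)phenyl (a 20-fold higher number from compound 3 to compound 4 (1.31 log units; beyond the scatter)) and against 3-chlorophenyl (a 31-fold higher number from compound 2 to compound 4 (1.49 log units; beyond the scatter)). The 4-fluorophenyl of compound 1 no longer marks the top of the range, as the change to 2-methoxyphenyl adds a further modest step (a 4.8-fold higher number from compound 1 to compound 4 (0.68 log units; beyond the scatter)). Nothing available accounts for this rise.

Within the data shown here, compound 4 is the only compound here that carries a methoxy group and the only one with a 2-substituted aryl, so the two features cannot be told apart. As far as these compounds go, how an unsubstituted phenyl, or an aryl group bearing an amine or a carboxylic acid, would stand on this nitrogen also remains open.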